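Moving one chlorine: what compound 3 may show

This account rests on a few compounds, and the source may have more. Where it says the series, first, only, none or still open, it means among the compounds named here.

In a functional assay on NCI-H460 cells (Homo sapiens) for cytotoxicity, read by sulforhodamine B assay (on this read-out higher numbers stand for weaker inhibition of growth and lower numbers for stronger inhibition of growth), compound 1 `CC1=CC[C@@H]([C@@](C)(O)CCCC(C)(C)NC(=S)N/N=C\c2ccc([N+](=O)[O-])cc2)CC1` gives 10100 nM and compound 2 `CC1=CC[C@@H]([C@@](C)(O)CCCC(C)(C)NC(=S)N/N=C\c2ccccc2Cl)CC1` gives 24600 nM. Among the compounds with values here, compound 2 therefore holds the higher of the only two numbers available, which means the weaker growth inhibition of the pair. Compound 3 `CC1=CC[C@@H]([C@@](C)(O)CCCC(C)(C)NC(=S)N/N=C\c2cccc(Cl)c2)CC1` shares its core with compound 2 and differs in one place: 3-chlorophenyl in place of 2-chlorophenyl on a carbon with a double bond to nitrogen. In plain terms, the same atoms are joined differently, with 3-chlorophenyl in place of 2-chlorophenyl on a carbon with a double bond to nitrogen.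

Within the data shown here, only one measured step offers any guidance: a 2.4-fold higher number from compound 1 to compound 2 (0.39 log units; beyond the scatter). That step is modest, and it brought in a different group rather than rearranging the same one. Among the measured compounds shown here, no measured pair isolates the kind of change made here, so the guide is a rough one. For the measured compounds named here, a change no larger than that step seems the sensible expectation, and no clear move beyond the scatter can be predicted. The expected change is a 1.2-fold lower number from compound 2 to compound 3 (0.09 log units; within the scatter). Compound 3 is estimated at 20000 nM, with an expected range of 9000 nM to 45000 nM.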

Compound 3, concentration for 50% growth inhibition: 44300 nM
Estimate against measurement, compound 3: 2.2-fold (0.35 log units) below; the measured number falls inside the stated range.
By their numbers in this assay, from the lowest: compound 1; then compounds 2 and 3 (each within the scatter of the next).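

In this assay, putting 3-chlorophenyl in place of 2-chlorophenyl gives a 1.8-fold higher number from compound 2 to compound 3 (0.26 log units; within the scatter) and so leaves the two chlorine placements indistinguishable in this small set. The comparison with 4-nitrophenyl is clearer, with a 4.4-fold higher number from compound 1 to compound 3 (0.64 log units; beyond the scatter) alongside a 2.4-fold higher number from compound 1 to compound 2 (0.39 log units; beyond the scatter) so that compound 1, at the lowest number, stands apart from both chlorophenyl compounds by more than the usual scatter, meaning stronger inhibition of growth than either. No supporting measurement is available to explain these differences.

Within the data shown here, what remains open is whether the advantage of compound 1 belongs to the nitro group itself or to where that group sits, since compound 1 differs from compound 2 and compound 3 in both the group and its placement on the ring, and no compound here carries the same group at all three placements. It is also unknown how the shared core would respond to an amine or a carboxylic acid on the phenyl ring in place of the chlorine, or to a longer chain between the thiocarbonyl nitrogen and the hydroxyl-bearing carbon.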